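A few compounds are considered here, and "the series" means these few. Any claim that something is new, unique, unknown or untested is made for them only; others in the source may bear on it.

Measured so far:

Compound 1 `OCc1cc2cc(/C(=N\O)Nc3cccc(Cl)c3)ccc2o1` — 8000 nM
Compound 2 `OCc1cc2cc(/C(=N\O)Nc3cccc(Br)c3)ccc2o1` — 710 nM
Compound 3 `O/N=C(/Nc1cccc(Cl)c1)c1ccc2oc(-c3ccccc3)cc2c1` — 900 nM

All three were tested in an assay on isolated protein for inhibition of Indoleamine 2,3-dioxygenase 1 (Homo sapiens), read by spectrophotometry; a higher number here means a weaker inhibitor, a lower number a stronger inhibitor. Compound 2 differs from compound 1 by bromo in place of chloro on an aromatic carbon, and this change gave an 11-fold lower number from compound 1 to compound 2 (1.05 log units; beyond the scatter). Compound 3 differs from compound 1 by phenyl in place of hydroxymethyl on an aromatic carbon, giving an 8.9-fold lower number from compound 1 to compound 3 (0.95 log units; beyond the scatter). Compound 4 `O/N=C(/Nc1cccc(Br)c1)c1ccc2oc(-c3ccccc3)cc2c1` has not yet been measured; it differs from compound 3 by bromo in place of chloro on an aromatic carbon, the same change as between compound 1 and compound 2, at the same place, on a different core. Among the compounds with values here, for compound 4 the expected step is a 6.0-fold lower number from compound 3 to compound 4 (0.78 log units; beyond the scatter), a little smaller than the earlier one, because the value of compound 3 900 nM already stands well below that of compound 1 and only one example of this change is known. Compound 4 is therefore estimated at 150 nM, with a likely range from 50 nM to 500 nM.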

Compound 4, half-maximal inhibitory concentration: 900 nM
Compound 4: middle estimate off by 6.0-fold (0.78 log units), on the low side, outside the stated range (above it).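

In this assay, bromo in place of chloro gave no change at the digits printed from compound 3 to compound 4 (within the scatter), so the change did not carry over from the core of compound 1 to the core of compound 3: the same change on two cores in this assay, an 11-fold lower number (1.05 log units; beyond the scatter) from compound 1 to compound 2 and no change at the digits printed (within the scatter) from compound 3 to compound 4, 11-fold (1.05 log units) apart, beyond the scatter of two such steps. Phenyl in place of hydroxymethyl likewise gave a 1.3-fold higher number from compound 2 to compound 4 (0.10 log units; within the scatter), much less than its step on the chloro compounds: the same change on two cores in this assay, an 8.9-fold lower number (0.95 log units; beyond the scatter) from compound 1 to compound 3 and a 1.3-fold higher number (0.10 log units; within the scatter) from compound 2 to compound 4, 11-fold (1.05 log units) apart, beyond the scatter of two such steps. These two gaps come from the same four compounds, so they are one observation rather than two, and they show neither why the changes fail to add up nor how either change behaves on any other core.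

The compounds shown leave open whether other groups in place of the phenyl, such as a methyl or a carboxylic acid, would restore the bromo step. They also leave open how fluoro or iodo in place of chloro would behave on either core.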